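Shortening the Oxime Ether Chain to a Free Hydroxyl

A few compounds are considered here, and "the series" means these few. Any claim that something is new, unique, unknown or untested is made for them only; others in the source may bear on it.

Measured so far in a functional assay on HCT-116 cells (Homo sapiens) for antiproliferative activity; on this read-out higher numbers stand for weaker inhibition and lower numbers for stronger inhibition:
- compound 1 `COCCCO/N=C/c1c(N)ncnc1Oc1ccc2[nH]c(C)cc2c1F` gives 438 nM
- compound 2 `CO/N=C/c1c(N)ncnc1Oc1ccc2[nH]ccc2c1F` gives 365 nM

Compound 1 has the higher of the two numbers in this assay, but its gap to compound 2 lies within the usual scatter of repeated measurements, so the two values cannot be told apart with confidence. The two compounds also differ in more than one place, so no single change can be read from their pair.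

Compound 3 `Cc1cc2c(F)c(Oc3ncnc(N)c3/C=N/OCCO)ccc2[nH]1` has not yet been measured. It keeps the whole core of compound 1 and changes only the tail of the oxime ether: hydroxy in place of methoxymethyl on a saturated chain carbon, two bonds along the chain from an oxygen on an unsaturated carbon. Cut one bond further out, the same difference reads as 3-methoxypropoxy becoming 2-hydroxyethoxy.

For the measured compounds named here, no measured pair shows what this kind of change does here, so the expectation rests on compound 1 alone. The step of a 1.1-fold higher number from compound 1 to compound 3 (0.06 log units; within the scatter) is expected to stay within the scatter, with no clear direction. Compound 3 is therefore expected to give 500 nM in this assay, within a range of 180 nM to 1400 nM.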

Compound 3, half-maximal inhibitory concentration: 323 nM
Beside the measured number, compound 3's estimate is 1.5-fold (0.19 log units) above it, within the range that was stated.
By their numbers in this assay, from the lowest: compounds 3, 2 and 1 (each within the scatter of the next).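

In this assay the swap of 3-methoxypropoxy for 2-hydroxyethoxy on the shared core gives a 1.4-fold lower number from compound 1 to compound 3 (0.13 log units; within the scatter) and this step lies within the usual scatter, so the two compounds cannot be told apart. For the compounds shown here, this is the first comparison at this position in which only one place differs, and it shows that the read-out stays within the scatter when methoxymethyl gives way to hydroxy on a saturated chain carbon, even though hydroxy brings a hydrogen-bond donor that methoxymethyl lacks. No independent measurement is available to explain the outcome of this change. Still open, going by these compounds, is whether this tolerance extends to other chain ends, such as an amine or a carboxylic acid in place of the hydroxy, or to a longer chain that ends in hydroxy. Compound 2 differs from compound 3 in more than one place, so that pair cannot be read as a single change, and a single step cannot show how the tail behaves on any other core.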